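Swapping Benzoyl for Carbamoyl on Compound 3

The source may report more compounds than this note shows. Statements on the series, on what has been measured and on what is new or still open speak of the compounds shown alone.

In a functional assay on HCT-116 cells (Homo sapiens) for inhibition, read by sulforhodamine B assay, with a stated time of 48 h, tested at 50 uM (on this read-out lower numbers stand for less inhibition of growth and higher numbers for more inhibition of growth at the one concentration tested), compound 1 `COc1cc2c(cc1CCC(C)C)C(=O)C[C@@H](c1ccc(O)cc1)O2` gives 77% and compound 2 `COc1ccc([C@@H]2CC(=O)c3cc(CC=C(C)C)c(OC)cc3O2)cc1` gives 68% while compound 3 `COc1ccc([C@@H]2C/C(=N/OCc3cn(-c4ccc(C(=O)c5ccccc5)cc4)nn3)c3cc(CC=C(C)C)c(OC)cc3O2)cc1` gives 52% as the lowest of the three, with its gaps to both others beyond the scatter. Compound 4 `COc1ccc([C@@H]2C/C(=N/OCc3cn(-c4ccc(C(N)=O)cc4)nn3)c3cc(CC=C(C)C)c(OC)cc3O2)cc1` is still unmeasured. It differs from compound 3 in one place, with amino in place of phenyl on a carbonyl carbon, so that benzoyl becomes carbamoyl amino in place of phenyl on a carbonyl carbon and the rest stays the same. For the measured compounds named here, no measured pair of compounds shows this change, which leaves the expectation loose. The expected step of a number 4 percentage points higher from compound 3 to compound 4 (within the scatter) is a small rise in this assay that stays within the scatter. Compound 4 is estimated at 56% with an expected range of 40% to 72% for the coming measurement.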

Compound 4, percent growth inhibition at one concentration: 100%
Compound 4: the middle estimate sits 44 percentage points below what was measured; measured number above the stated range.
By their numbers in this assay, from the lowest: compound 3; then compounds 2 and 1 (each within the scatter of the next); then compound 4.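

In this assay, putting amino in place of phenyl on a carbonyl carbon gives a number 48 percentage points higher from compound 3 to compound 4 (beyond the scatter), so a single change at this place can move growth inhibition by a large amount. For the compounds shown here, this is the first view of that place, as no earlier pair of compounds differed there. Nothing available explains the size of this step.

From the compounds shown here alone, whether a methylamide or a carboxylic acid in the same place would match compound 4 remains open. Going by these compounds, with compound 4 at 100% at one concentration, its standing at lower concentrations also remains open.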